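The source may hold more compounds than are shown below. What is called first, only, known or untested is meant among the compounds shown, and "the series" means these compounds.

The set comprises compound 1 `Cc1nc(-c2ccccc2)c(CNCCN2CCN(C(c3ccccc3)c3ccccc3)CC2)o1` and compound 2 `CCCc1nc(-c2ccccc2)c(CNCCCN2CCN(c3cccc(C(F)(F)F)c3)CC2)o1`, both measured in an assay on HEK293 cells for inhibition of Voltage-dependent T-type calcium channel subunit alpha-1G (Homo sapiens), read by fluorescence, tested at 10 uM (a higher number here means more inhibition at the concentration tested (going by the name of the read-out), a lower number less inhibition), and compound 3 `CCCc1nc(-c2ccccc2)c(CNCCCN2CCN(c3cccc(C)c3)CC2)o1`, which has not yet been measured. In this assay compound 1 gives 57.3%, and compound 2 gives 51.6%. Compound 2 thus shows the lower of the two numbers, but its gap to compound 1 lies within the scatter, so the two cannot be ranked against each other.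

Compound 3 arises from compound 2 by a single change: methyl in place of trifluoromethyl on an aromatic carbon. No measured pair among these compounds tells how such a change moves the read-out, so there is nothing to suggest a step beyond the scatter in either direction. The expected step from compound 2 to compound 3 is therefore a number 3.6 percentage points lower from compound 2 to compound 3 (within the scatter), small and uncertain. For compound 3 the estimate is 48%, with a range from 28% to 66%.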

Compound 3, a percentage reported as inhibition, at one concentration (the size of the read-out at that concentration, not a potency): 47.8%
For compound 3 the middle estimate is 0.2 percentage points above the measured one; low and high end bracket the measured number.
By their numbers in this assay, from the lowest: compounds 3, 2 and 1 (each within the scatter of the next).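

In this assay, for the compounds shown here, the first measured step at this place on the aromatic ring, meta to a large group, reads a number 3.8 percentage points lower from compound 2 to compound 3 (within the scatter). On this one pair, going from 3-(trifluoromethyl)phenyl to 3-methylphenyl, and so from 4 heavy atoms to 1, leaves the read-out within the scatter, and the two groups cannot be told apart at the concentration tested. Nothing in the data offers an explanation for this result.

From the compounds shown here alone, whether another group at this place, such as methoxy, chlorine, an amine or a carboxylic acid, would move the read-out beyond the scatter stays open. Going by these compounds, it is equally open whether the same change would stay this small with a shorter or longer chain in place of those shared by compound 2 and compound 3.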